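One Fluorine Less on a Compound at the Limit

A few compounds are considered here, and "the series" means these few. Any claim that something is new, unique, unknown or untested is made for them only; others in the source may bear on it.

The study brings together three measured compounds and one still to be measured in a functional assay on CCRF-CEM cells (Homo sapiens) for cytotoxicity, in the absence of a further agent; a lower number here means a stronger inhibitor, a higher number a weaker inhibitor. Compound 1 `Nc1nc(N)c(CCCN(Cc2ccc(NC(CCC(=O)O)C(=O)O)cc2)c2cc(F)c(F)cc2[N+](=O)[O-])c(O)n1` gives > 100000 nM, which is a limit of the assay rather than a number. Compound 2 `Nc1nc(N)c(CCCNc2cc(F)c(F)cc2[N+](=O)[O-])c(O)n1` gives > 100000 nM, again only a limit. Among the measured compounds shown here, compound 3 `COC(=O)c1ccc(CN(CCCc2c(N)nc(N)nc2O)c2cc(F)c(F)cc2[N+](=O)[O-])cc1` is the one compound with a numerical result, 55000 nM. The two steps leading to compound 3 are an at least 1.8-fold lower number from compound 1 to compound 3 (0.25 log units; that floor lies within the scatter) and an at least 1.8-fold lower number from compound 2 to compound 3 (0.25 log units; that floor lies within the scatter); both start from the limit of > 100000 nM in this assay, at which 2 of the 3 values shown sit, so their true size cannot be known.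

Compound 4 `Nc1nc(N)c(CCCN(Cc2ccc(NC(CCC(=O)O)C(=O)O)cc2)c2cc(F)ccc2[N+](=O)[O-])c(O)n1` differs from compound 1 by hydrogen in place of fluoro on an aromatic carbon. Neither measured step touches this part of the molecule: one puts methoxycarbonyl in place of (1,3-dicarboxypropyl)amino on an aromatic carbon, the other puts 4-(methoxycarbonyl)benzyl in place of hydrogen on a nitrogen on an aromatic ring. For the measured compounds named here, no measured step therefore bears directly on the change from compound 1 to compound 4, and the starting point is itself only a bound. On this basis one expects no step beyond the scatter in this assay, in either direction. Compound 4 is estimated at 150000 nM, within 50000 nM to 500000 nM, and most probably reported again as a limit. That estimate means a step that the limit leaves unreadable from compound 1 to compound 4, a step expected to stay within the scatter.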

Compound 4, half-maximal inhibitory concentration: > 100000 nM
Compound 4 ended at the assay's limit; the forecaster's own chance of this, stated with the estimate: 80%; the middle value is on the limit's open side.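

In this assay compound 4 gives > 100000 nM, which is a limit of the assay and not a number. Among the compounds shown here, compound 1 also stands at a limit, so no step between compound 1 and compound 4 can be read: the limit of > 100000 nM in this assay, at which 3 of the 4 values shown sit. As far as these compounds go, whether hydrogen in place of fluoro changes the result in this assay at all stays open.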